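Removing the Methyl from an Inactive Benzoyl Thiourea

The source may hold more compounds than are shown below. What is called first, only, known or untested is meant among the compounds shown, and "the series" means these compounds.

Compound 1, `Cc1ccc(-c2nc3ccccc3[nH]2)cc1NC(=S)NC(=O)c1ccc2c(c1)OCCO2`, anchors this small series. In a functional assay on HUVEC cells (Homo sapiens) for cytotoxicity, read by WST assay, with a stated time of 48 h (a higher number here means a weaker inhibitor, a lower number a stronger inhibitor), compound 1 gives 240 nM. Compound 2, `Cc1ccc(-c2nc3ccccc3[nH]2)cc1NC(=S)NC(=O)c1ccccc1`, differs from it only at the carbonyl carbon, where phenyl stands in place of 2,3-dihydro-1,4-benzodioxin-6-yl. For compound 2 the assay reports no number but a limit, > 10000 nM. For the measured compounds named here, the single measured step is thus an at least 41-fold higher number from compound 1 to compound 2 (1.61 log units; beyond the scatter), and it ends at the limit of > 10000 nM in this assay, at which 1 of the 2 values shown sits, so compound 2 stands at the weak edge of what the numbers can show.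

Compound 3, `O=C(NC(=S)Nc1cccc(-c2nc3ccccc3[nH]2)c1)c1ccccc1`, keeps the plain benzoyl of compound 2 and alters the other ring instead: hydrogen in place of methyl on an aromatic carbon. Going by the values given here, no measured step touches that methyl; the only step known concerns the carbonyl side and is large. Nothing in the data suggests that losing the methyl would pull compound 3 back into the measurable range. The step that the limit leaves unreadable from compound 2 to compound 3 is therefore expected to stay within the scatter, most likely as another limit. Compound 3 is estimated in this assay at 20000 nM, between 8000 nM and 60000 nM.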

Compound 3, half-maximal inhibitory concentration: > 10000 nM
Compound 3: a limit, no number; the forecaster's own chance of this, stated with the estimate: 80%; the middle value lies beyond the limit too.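

In this assay compound 3 gives > 10000 nM, a limit and not a number. Compound 2 also stands at a limit, so no step can be read between compound 2 and compound 3: the limit of > 10000 nM in this assay, at which 2 of the 3 values shown sit. The compounds shown leave open where either compound truly lies, and so whether hydrogen in place of methyl changes anything.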